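Bromophenyl for methoxyphenyl at the second arm of compound 2

The source may hold more compounds than are shown below. What is called first, only, known or untested is meant among the compounds shown, and "the series" means these compounds.

Three members of the series have been measured in a functional assay on K562 cells (Homo sapiens) for cytotoxicity, read by CCK-8 assay, with a stated time of 72 h; on this read-out lower numbers stand for stronger inhibition and higher numbers for weaker inhibition. Compound 1 `C=CCn1c(=O)/c(=C\c2cc(F)ccc2C)[nH]c(=O)/c1=C\c1ccccc1OC` gives 1800 nM, compound 2 `C=CCn1c(=O)/c(=C\c2cccc(Br)c2)[nH]c(=O)/c1=C\c1ccccc1OC` gives 2400 nM, and compound 3 `C=CCn1c(=O)/c(=C\c2ccccc2OC)[nH]c(=O)/c1=C\c1ccccc1OC` gives 7400 nM. Among these numbers compound 2 stands second highest: the step of a 1.3-fold higher number from compound 1 to compound 2 (0.12 log units; within the scatter) lies within the scatter, whereas a 3.1-fold higher number from compound 2 to compound 3 (0.49 log units; beyond the scatter) lies beyond it. Compound 4 `C=CCn1c(=O)/c(=C\c2cccc(Br)c2)[nH]c(=O)/c1=C\c1cccc(Br)c1` remains to be measured. Its change from compound 2: 3-bromophenyl in place of 2-methoxyphenyl on a double-bonded chain carbon bound to an aromatic carbon. The step that bears most directly on this change is a 3.1-fold higher number from compound 2 to compound 3 (0.49 log units; beyond the scatter), read in reverse, as it exchanges the same two groups at a place of the same kind; a 4.1-fold higher number from compound 1 to compound 3 (0.61 log units; beyond the scatter) points the same way, with 2-methoxyphenyl again at the higher number. A lower number is therefore expected for compound 4, and the estimated step is a 2.7-fold lower number from compound 2 to compound 4 (0.43 log units; beyond the scatter). Compound 4 is estimated at 900 nM, with a range from 400 nM to 2200 nM.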

Compound 4, half-maximal inhibitory concentration: "not active" (no number reported)
Compound 4: no number reported; the estimate stays without a comparison.
By their numbers in this assay, from the lowest: compounds 1 and 2 (each within the scatter of the next); then compound 3.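

In this assay, going by these compounds alone, compound 4 is reported as "not active" without a number, so no step from compound 2 to compound 4 can be read. The compounds shown leave open how far compound 4 lies from compound 2 on this read-out. Nothing shown bears on the reason for this result.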